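From chloro to bromo at the assay limit

This account rests on a few compounds, and the source may have more. Where it says the series, first, only, none or still open, it means among the compounds named here.

Measured so far in an ADME assay on BHK-21 cells (Mesocricetus auratus) for cytotoxicity, read by MTT assay, with a stated time of 72 h; on this read-out lower numbers stand for higher toxicity in this test and higher numbers for lower toxicity in this test:
Compound 1 `Cc1ccc(NCc2cn(-c3ccccc3)nc2-c2ccc(Cl)cc2)cc1`: > 100000 nM
Compound 2 `Clc1ccc(NCc2cn(-c3ccccc3)nc2-c2ccc(Cl)cc2)cc1`: 73000 nM

The entry for compound 1 is a limit and not a number: it stands at the limit of > 100000 nM in this assay, at which 1 of the 2 values shown sits. Compound 3 `Cc1ccc(NCc2cn(-c3ccccc3)nc2-c2ccc(Br)cc2)cc1` keeps the core of compound 1 and alters a single group, (bromo in place of chloro on an aromatic carbon). This is bromo in place of chloro on an aromatic carbon, para to a large group.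

Going by the values given here, only one measured step can guide the expectation, and only loosely. It runs as an at least 1.3-fold lower number from compound 1 to compound 2 (0.13 log units; that floor lies within the scatter). Among the compounds with values here, that swap, chloro in place of methyl, touches a different group from the one that changes here, and no swap of chloro for bromo has been measured. No step beyond the scatter is therefore expected in this assay. The expected step is a number no higher from compound 1 to compound 3 (the limit leaves the size open). Compound 3 is estimated at 100000 nM, with an expected range from 50000 nM to 200000 nM.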

Compound 3, half-maximal cytotoxic concentration: > 100000 nM
Compound 3 was reported as a limit; the forecaster's own chance of this, stated with the estimate: 50%; the middle value sits exactly at the limit.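

In this assay, compound 1 and compound 3 are each reported as a limit and not a number, so no step between them can be read: the limit of > 100000 nM in this assay, at which 2 of the 3 values shown sit.

The compounds shown leave open whether bromo in place of chloro changes this toxicity read-out at all, and by how much.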